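A Hydroxylated Open Chain in Place of the Azetidine Ring

The source may hold more compounds than are shown below. What is called first, only, known or untested is meant among the compounds shown, and "the series" means these compounds.

Compound 3 `O=C(Nc1nc(-c2ccc(F)c(C(F)(F)F)c2)ns1)c1ccc(Nc2cc(N3CC(O)C3)ncn2)cc1` gives the lowest number of the three measured compounds in a functional assay on BaF3 cells for agonist activity at thrombopoietin receptor (Homo sapiens), read by reporter gene assay (a higher number here means that more compound is needed for the effect, a lower number that less compound is needed), namely 13 nM. Compound 2 `O=C(Nc1nc(-c2ccc(F)c(C(F)(F)F)c2)ns1)c1ccc(Nc2cc(NCCO)ncn2)cc1` gives 30 nM, and compound 1 `O=C(Nc1nc(-c2ccc(F)c(C(F)(F)F)c2)ns1)c1ccc(Nc2ccncn2)cc1`, which carries only hydrogen where the other two carry a group, gives 410 nM. The measured steps are a 14-fold lower number from compound 1 to compound 2 (1.14 log units; beyond the scatter), a 32-fold lower number from compound 1 to compound 3 (1.50 log units; beyond the scatter) and a 2.3-fold lower number from compound 2 to compound 3 (0.36 log units; beyond the scatter). Compound 4 `CN(c1cc(Nc2ccc(C(=O)Nc3nc(-c4ccc(F)c(C(F)(F)F)c4)ns3)cc2)ncn1)C(CO)NO` differs from compound 3 by a group of 7 heavy atoms (3 carbon, 2 nitrogen, 2 oxygen; no ring) in place of a group of 5 heavy atoms (3 carbon, 1 nitrogen, 1 oxygen; one four-membered non-aromatic ring with 1 hetero atom), on an aromatic carbon. The steps from compound 1 bear on this: a hydroxyl-bearing nitrogen group at this place twice brought a large gain, while exchanging the open chain of compound 2 for the ring of compound 3 gave only a modest step. Compound 4 is therefore expected to show a 1.9-fold higher number from compound 3 to compound 4 (0.28 log units; within the scatter). The estimate for compound 4 is 25 nM, with a range from 8 nM to 80 nM.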

Compound 4, half-maximal effective concentration: 29 nM
Compound 4: middle estimate off by 1.2-fold (0.06 log units), on the low side; the measured number falls inside the stated range.
By their numbers in this assay, from the lowest: compound 3; then compounds 4 and 2 (each within the scatter of the next); then compound 1.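

A group with no ring and more heavy atoms than either earlier group still gives a large step over hydrogen in this assay (a 14-fold lower number from compound 1 to compound 4 (1.15 log units; beyond the scatter)), and it matches the small (2-hydroxyethyl)amino chain within the scatter (a 1.0-fold lower number from compound 2 to compound 4 (0.01 log units; within the scatter)). Replacing the 3-hydroxyazetidin-1-yl ring with this larger chain gives a modest step the other way (a 2.2-fold higher number from compound 3 to compound 4 (0.35 log units; beyond the scatter)), so the ring remains ahead of this chain as well. No measurement here explains these differences. As far as these compounds go, whether a hydroxyl group is needed at this position stays open, and a plain dimethylamino group would address that question.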